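Ethoxy replacing cyclohexyl on a thiophene-bearing amine series

A few compounds are considered here, and "the series" means these few. Any claim that something is new, unique, unknown or untested is made for them only; others in the source may bear on it.

Three compounds sharing one core have been examined in an ADME assay on MDCK cells (Canis lupus familiaris) for cytotoxicity, read by microscopy, with a stated time of 48 h; a higher number here means that more compound is tolerated, a lower number that less compound is tolerated. Compound 1, `CSc1ccc(CN[C@@H]2C[C@H]3C[C@@H]([C@H]2C)C3(C)C)s1`, gives 25000 nM. Compound 2, `C[C@H]1[C@H](NCc2sccc2C2CCCCC2)C[C@H]2C[C@@H]1C2(C)C`, gives 1560 nM. Compound 3, `Cc1n[nH]cc1CN[C@@H]1C[C@H]2C[C@@H]([C@H]1C)C2(C)C`, gives only a limit of the assay, > 100000 nM. Among the two compounds that give a number, compound 2 stands lowest, with compound 1 sitting well beyond the scatter above it. The value for compound 3 is a limit, at which one of the three values sits (the limit of > 100000 nM in this assay, at which 1 of the 3 values shown sits).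

Compound 4, `CCOc1ccsc1CN[C@@H]1C[C@H]2C[C@@H]([C@H]1C)C2(C)C`, has not yet been measured in this assay. Its structure differs from compound 2 in one place: ethoxy in place of cyclohexyl on an aromatic carbon. Going by the values given here, no step between two measured compounds isolates this kind of exchange, so the expectation for compound 4 rests on where compound 2 and compound 1 stand. The ethoxy group is the smaller substituent, and compound 1 with its methylsulfanyl group is tolerated at a markedly higher concentration than compound 2. The step from compound 2 to compound 4 is therefore expected to be upward, a 13-fold higher number from compound 2 to compound 4 (1.11 log units; beyond the scatter), beyond the scatter. Compound 4 is estimated to give 20000 nM in this assay, within a range from 5000 nM to 80000 nM.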

Compound 4, minimum cytotoxic concentration: 50000 nM
Compound 4: middle estimate off by 2.5-fold (0.40 log units), on the low side, and the stated range covers the measured number.
By their numbers in this assay, from the lowest: compound 2; then compounds 1 and 4 (each within the scatter of the next). At a limit, above all of these: compound 3.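

In this assay, going by these compounds alone, the exchange of cyclohexyl for ethoxy on an aromatic carbon of the five-membered aromatic ring with one sulfur gives the first step that changes one place only: a 32-fold higher number from compound 2 to compound 4 (1.51 log units; beyond the scatter). Within the data shown here, this step is large and lies beyond the scatter, so the group at this position, two ring bonds from the ring sulfur, clearly matters for how much compound the cells tolerate, which the earlier compounds could not show on their own. The measurements shown offer no reason for the size of this step.

The exchange removes a carbon-only ring, shortens the substituent and brings in an oxygen that is a hydrogen-bond acceptor, all at once, so this single step cannot tell which of these changes goes with the higher number. Going by these compounds, it remains open where a propyl chain, which has no oxygen, or a tetrahydropyranyl group, which keeps a six-membered ring and carries an oxygen, would stand at this same place.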